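The source may hold more compounds than are shown below. What is called first, only, known or untested is meant among the compounds shown, and "the series" means these compounds.

Among the measured compounds shown here, compound 3 `C/C=C/C(=O)N(Cc1ccc(OC)c(O)c1)c1cc(OC)c(OC)c(OC)c1` gives 67 nM in a functional assay on KYSE-450 cells (Homo sapiens) for inhibition, read by MTT assay, with a stated time of 48 h (a lower number here means a stronger inhibitor, a higher number a weaker inhibitor), the lowest number among the three compounds measured so far; compound 1 `COc1ccc(CN(C(C)=O)c2cc(OC)c(OC)c(OC)c2)cc1O` gives 160 nM and compound 2 `COc1ccc(CN(C(=O)CCCCCl)c2cc(OC)c(OC)c(OC)c2)cc1O` gives 770 nM. Compound 4 `CC/C=C/C(=O)N(Cc1ccc(OC)c(O)c1)c1cc(OC)c(OC)c(OC)c1` differs from compound 3 in one place: methyl in place of hydrogen on a saturated chain carbon bound to a double-bonded chain carbon. For the measured compounds named here, two measured steps bear on this change. The step of a 2.4-fold lower number from compound 1 to compound 3 (0.38 log units; beyond the scatter) shows a modest gain when the unsaturated chain replaced the methyl, whereas the step of a 4.8-fold higher number from compound 1 to compound 2 (0.68 log units; beyond the scatter) shows a loss when a saturated chain grew longer. Adding a single methyl is a far smaller extension than that second step, so the expected step of a 1.3-fold higher number from compound 3 to compound 4 (0.13 log units; within the scatter) is small, most likely a slight weakening that stays within the scatter. Compound 4 is therefore estimated at 90 nM, with a range from 40 nM to 220 nM.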

Compound 4, half-maximal inhibitory concentration: 72 nM
Beside the measured number, compound 4's estimate is 1.3-fold (0.10 log units) above it; the measured number falls inside the stated range.
By their numbers in this assay, from the lowest: compounds 3 and 4 (each within the scatter of the next); then compound 1; then compound 2.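

In this assay, methyl in place of hydrogen on a saturated chain carbon bound to a double-bonded chain carbon makes no difference that can be told from scatter (a 1.1-fold higher number from compound 3 to compound 4 (0.03 log units; within the scatter)), so this position accepts the added carbon. The but-1-en-1-yl group also keeps the advantage seen with prop-1-en-1-yl over methyl (a 2.2-fold lower number from compound 1 to compound 4 (0.35 log units; beyond the scatter)) and over 4-chlorobutyl (an 11-fold lower number from compound 2 to compound 4 (1.03 log units; beyond the scatter)). No measurement here explains these steps. Still open, as far as these compounds go, is whether a longer unsaturated chain, such as hex-1-en-1-yl, or an amine at the chain end would hold this level.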